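The source may report more compounds than this note shows. Statements on the series, on what has been measured and on what is new or still open speak of the compounds shown alone.

Compound 1 `Cc1cccc(-c2nc3c(=O)[nH]c(C)nc3s2)c1`: 1%
Compound 2 `Cc1nc2sc(-c3cccc(C(F)(F)F)c3)nc2c(=O)[nH]1`: 1%
Compound 3 `Cc1nc2sc(-c3ccco3)nc2c(=O)[nH]1`: 37%

In an assay on CHO cells for displacement of a labelled ligand from adenosine receptor A1 (Homo sapiens), read by scintillation counting, with a stated time of 120 min, tested at 1 uM (a lower number here means less inhibition, a higher number more inhibition at the concentration tested (going by the name of the read-out)), compound 3 gives 37%, the highest of the three numbers. Compound 1 gives 1% and compound 2 gives 1%, each beyond the scatter below compound 3. Compound 4 `Cc1nc2sc(-c3cccs3)nc2c(=O)[nH]1` differs from compound 3 by thiophen-2-yl in place of furan-2-yl on an aromatic carbon. For the measured compounds named here, the only measured step, no change at the digits printed from compound 1 to compound 2 (within the scatter), concerns a different group and shows no change, so no measured step bears directly on exchanging one five-membered ring for another. With nothing to point to a shift, compound 4 is expected to land close to compound 3, the step being a number 2 percentage points lower from compound 3 to compound 4 (within the scatter), within the scatter. Compound 4 is therefore estimated at 35%, with a range from 15% to 60%.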

Compound 4, a percentage reported as inhibition, at one concentration (the size of the read-out at that concentration, not a potency): 4%
Compound 4: middle estimate off by 31 percentage points, on the high side, outside the stated range (below it).
By their numbers in this assay, from the lowest: compounds 1, 2 and 4 (each within the scatter of the next); then compound 3.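

In this assay, thiophen-2-yl in place of furan-2-yl gives a number 33 percentage points lower from compound 3 to compound 4 (beyond the scatter) on the shared core. The two groups have the same count of heavy atoms and differ in one ring atom, sulfur for oxygen, so this position can separate two closely matched five-membered aromatic rings. The earlier exchange of methyl for trifluoromethyl, at a different place, showed no such separation.

On these data alone, whether an amine, a carboxylic acid or a pyrrole ring at this position would keep or lose the inhibition seen with compound 3 remains open. Nothing measured here explains the gap between the furan-2-yl and thiophen-2-yl compounds.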